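Dichlorophenyl in Place of Dimethylphenyl in a Dopamine Series

The source may report more compounds than this note shows. Statements on the series, on what has been measured and on what is new or still open speak of the compounds shown alone.

Compounds measured in a functional assay on HEK293 cells with D(4) dopamine receptor (Homo sapiens) as the target, read by FLIPR; on this read-out lower numbers stand for an effect already at smaller amounts and higher numbers for an effect only at larger amounts of compound:
compound 1, `CO/N=C(\CCN1CCN(c2ccccn2)CC1)c1ccccc1Cl`: 42.3 nM
compound 2, `CO/N=C(\CCN1CCN(c2ccccn2)CC1)c1ccccc1C`: 74 nM
compound 3, `CO/N=C(\CCN1CCN(c2ccccn2)CC1)c1cc(C)cc(C)c1`: 175 nM

Compound 3 stands at the highest of the three numbers. Its nearest neighbour is compound 2, separated by a 2.4-fold higher number from compound 2 to compound 3 (0.37 log units; beyond the scatter), and the larger gap is a 4.1-fold higher number from compound 1 to compound 3 (0.62 log units; beyond the scatter). Both of those steps exchange the aryl group on the carbon with a double bond to nitrogen, and both went upward beyond the scatter.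

Compound 4, `CO/N=C(\CCN1CCN(c2ccccn2)CC1)c1ccc(Cl)c(Cl)c1`, has not been measured. Its change from compound 3 is 3,4-dichlorophenyl in place of 3,5-dimethylphenyl on a carbon with a double bond to nitrogen. Among the compounds with values here, no measured pair exchanges one substitution pattern for this one on the same ring, so the steps ending at compound 3 bear on it only loosely. The closest guide for chloro against methyl is a 1.7-fold higher number from compound 1 to compound 2 (0.24 log units; within the scatter), which stayed within the scatter. The expectation for this assay is therefore a step of no clear direction, if anything slightly downward, because a 1.7-fold higher number from compound 1 to compound 2 (0.24 log units; within the scatter) put the chloro compound at the lower number.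

Compound 4 is thus expected to give about 130 nM, with a range from 45 nM to 400 nM. That estimate corresponds to an expected step of a 1.3-fold lower number from compound 3 to compound 4 (0.13 log units; within the scatter).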

Compound 4, half-maximal effective concentration: 542 nM
For compound 4 the middle estimate is 4.2-fold (0.62 log units) below the measured one; the measured number lies above the stated range.
By their numbers in this assay, from the lowest: compounds 1 and 2 (each within the scatter of the next); then compound 3; then compound 4.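

In this assay, the aryl group on the carbon with a double bond to nitrogen moved the number beyond the scatter even though the heavy-atom count stayed the same and neither group has hydrogen-bond donors or acceptors (a 3.1-fold higher number from compound 3 to compound 4 (0.49 log units; beyond the scatter)). Chlorine on the ring therefore does not by itself go with the lower number: the chloro-for-methyl exchange between the two monosubstituted rings stayed within the scatter (a 1.7-fold higher number from compound 1 to compound 2 (0.24 log units; within the scatter)), whereas 3,4-dichlorophenyl gave the highest number of the series, both against 2-methylphenyl (a 7.3-fold higher number from compound 2 to compound 4 (0.86 log units; beyond the scatter)) and in a large step against 2-chlorophenyl (a 13-fold higher number from compound 1 to compound 4 (1.11 log units; beyond the scatter)). No supporting data on the reason for this rise are available.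

The compounds shown contain no pair with the same substitution pattern and only chloro exchanged for methyl on a disubstituted ring, so the roles of the kind of group and its placement cannot be separated here. As far as these compounds go, how a plain phenyl, or a ring carrying a methoxy group or a fluoro group, would compare on the same core also remains open.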